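This account rests on a few compounds, and the source may have more. Where it says the series, first, only, none or still open, it means among the compounds named here.

Measured in a functional assay on HeLa cells (Homo sapiens) for inhibition, read by sulforhodamine B assay; on this read-out lower numbers stand for stronger inhibition and higher numbers for weaker inhibition:
- compound 1 `O=C1C(NCc2ccccc2)=CC(=O)c2c1nc1n2[C@H]2OC[C@@H](O)[C@H]2OC1`: 11000 nM
- compound 2 `O=C1C(NC2CCCCC2)=CC(=O)c2c1nc1n2[C@H]2OC[C@@H](O)[C@H]2OC1`: > 16000 nM

Compound 2 stands at > 16000 nM, which is a limit of the assay and not a number. Compound 3 `O=C1C(Nc2cccc(F)c2)=CC(=O)c2c1nc1n2[C@H]2OC[C@@H](O)[C@H]2OC1` differs from it by 3-fluorophenyl in place of cyclohexyl on an amine nitrogen. Within the data shown here, only one measured step bears on this: an at least 1.4-fold higher number from compound 1 to compound 2 (0.16 log units; that floor lies within the scatter). It gives no size beyond the scatter, so only a modest step towards a lower number is expected in this assay, and perhaps none beyond the scatter. The expected change is an at least 1.6-fold lower number from compound 2 to compound 3 (0.20 log units; that floor lies within the scatter). Compound 3 is estimated at 10000 nM, with an expected range of 3500 nM to 28000 nM.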

Compound 3, half-maximal inhibitory concentration: > 8000 nM
Compound 3: a limit, no number; the forecaster's own chance of this, stated with the estimate: 35%; the middle value lies beyond the limit too.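

Among these compounds, compound 3 gives > 8000 nM in this assay, which is a limit of the assay and not a number, so no step from compound 1 or compound 2 to compound 3 can be read. The compounds shown leave open whether 3-fluorophenyl on the amine nitrogen differs from cyclohexyl or benzyl there.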